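This account rests on a few compounds, and the source may have more. Where it says the series, first, only, none or still open, it means among the compounds named here.

Measured so far in a functional assay on A549 cells (Homo sapiens) for inhibition, read by MTT assay, with a stated time of 72 h; on this read-out higher numbers stand for weaker inhibition and lower numbers for stronger inhibition 
- compound 1 `COc1cc(OC)c(C(=O)/C=C/c2ccccc2OC)c(OC)c1` gives 19800 nM 
- compound 2 `COc1cc(OC)c(C(=O)/C=C/c2ccc(O)c(O)c2)c(OC)c1` gives 8200 nM 
- compound 3 `COc1cc(OC)c(C(=O)/C=C/c2ccc(Cl)cc2)c(OC)c1` gives 13300 nM 

Compound 1 is separated from only one of the others (a 2.4-fold lower number from compound 1 to compound 2 (0.38 log units; beyond the scatter)). It stays within the scatter of the remaining one (a 1.5-fold lower number from compound 1 to compound 3 (0.17 log units; within the scatter)). Compounds 2 and 3 also cannot be told apart (a 1.6-fold higher number from compound 2 to compound 3 (0.21 log units; within the scatter)).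

Next is compound 4 `COc1cc(OC)c(C(=O)/C=C/c2ccccc2[N+](=O)[O-])c(OC)c1` with the change nitro in place of methoxy on an aromatic carbon (nitro in place of methoxy on an aromatic carbon, ortho to a large group). For the measured compounds named here, no measured step makes this exact exchange. The two steps out of compound 1 above are the closest guide, as both replace the 2-methoxyphenyl group. Both are small and both run towards a lower number, which suggests only a modest shift at most in this assay. The expected step is small, towards a lower number and probably within the scatter (a 1.5-fold lower number from compound 1 to compound 4 (0.18 log units; within the scatter)). For compound 4 the estimate is 13000 nM with an expected range of 5500 nM to 29000 nM.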

Compound 4, half-maximal inhibitory concentration: 10700 nM
For compound 4 the middle estimate is 1.2-fold (0.08 log units) above the measured one; low and high end bracket the measured number.
By their numbers in this assay, from the lowest: compounds 2, 4, 3 and 1 (each within the scatter of the next, the first and the last beyond it).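

In this assay the exchange of methoxy for nitro on this aromatic carbon, ortho to a large group, gives a step that stays within the scatter (a 1.9-fold lower number from compound 1 to compound 4 (0.27 log units; within the scatter)). For the compounds shown here, the earlier steps out of compound 1 replaced the whole 2-methoxyphenyl group, so this is the first reading of a single group exchanged at this place on that ring. Here, methoxy and nitro cannot be told apart, although nitro brings one double bond outside aromatic rings and more hydrogen-bond acceptors. Nothing available explains the size of this step.

On these data alone, whether an amine or a carboxylic acid on this aromatic carbon would move the number beyond the scatter remains open. As far as these compounds go, it is also open whether nitro on another carbon of the same ring would read the same.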